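Naphthalen-2-yl Hydrazone in Place of the Dimethylaminophenyl Arm

A few compounds are considered here, and "the series" means these few. Any claim that something is new, unique, unknown or untested is made for them only; others in the source may bear on it.

Compound 1 `C#CCSc1nc(N/N=C/c2ccc(N(C)C)cc2)c2nnn(Cc3ccccc3)c2n1`: 7620 nM
Compound 2 `CCCSc1nc(N/N=C/c2ccc(N(C)C)cc2)c2nnn(Cc3ccccc3)c2n1`: 13100 nM

In a functional assay on MGC-803 cells (Homo sapiens) for antiproliferative activity, read by MTT assay, with a stated time of 72 h (on this read-out lower numbers stand for stronger inhibition and higher numbers for weaker inhibition), compound 2 gives 13100 nM, while compound 1 gives 7620 nM; the step of a 1.7-fold higher number from compound 1 to compound 2 (0.24 log units; within the scatter) lies within the scatter, so the two compounds stand level. Compound 3 `CCCSc1nc(N/N=C/c2ccc3ccccc3c2)c2nnn(Cc3ccccc3)c2n1` differs from compound 2 by naphthalen-2-yl in place of 4-(dimethylamino)phenyl on a carbon with a double bond to nitrogen. Among the measured compounds shown here, no measured step touches this carbon; the only step on hand, a 1.7-fold higher number from compound 1 to compound 2 (0.24 log units; within the scatter), concerns the chain on the sulfur, so no direction is supported. Compound 3 is therefore expected to give about 15000 nM, within a wide range from 4000 nM to 60000 nM. The implied step, a 1.1-fold higher number from compound 2 to compound 3 (0.06 log units; within the scatter), is expected to stay within the scatter.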

Compound 3, half-maximal inhibitory concentration: > 64000 nM
Compound 3: a limit, no number (the forecaster's own chance of this, stated with the estimate: 15%); middle value at least 4.2-fold (0.63 log units) away from the limit.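

This is the first change shown on the carbon with a double bond to nitrogen, and in this assay naphthalen-2-yl in place of 4-(dimethylamino)phenyl gives an at least 4.8-fold higher number from compound 2 to compound 3 (0.68 log units; beyond the scatter). The position therefore responds to the group it carries, whereas the change on the chain on the sulfur gave a 1.7-fold higher number from compound 1 to compound 2 (0.24 log units; within the scatter). The value of compound 3 is a limit of the assay, not a number: the limit of > 64000 nM in this assay, at which 1 of the 3 values shown sits.

The compounds shown leave open whether an unsubstituted phenyl, or a phenyl carrying a methoxy group or a primary amine, would match compound 2. They also leave open whether naphthalen-2-yl would give the same result with the sulfur chain of compound 1.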